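Chain-end change from compound 1 to compound 4

The source may report more compounds than this note shows. Statements on the series, on what has been measured and on what is new or still open speak of the compounds shown alone.

Measured in a functional assay on EBC-1 cells (Homo sapiens) for antiproliferative activity, read by sulforhodamine B assay, with a stated time of 72 h; a higher number here means a weaker inhibitor, a lower number a stronger inhibitor:
- compound 1 `Cn1cc(-c2ccc(=O)n(CCOc3ccnc4cc(OCCCCCCC(=O)NO)ccc34)n2)cn1` gives 210 nM
- compound 2 `Cn1cc(-c2ccc(=O)n(CCOc3ccnc4cc(OCCCCCS)ccc34)n2)cn1` gives 640 nM
- compound 3 `CC(=O)CCCCCOc1ccc2c(OCCn3nc(-c4cnn(C)c4)ccc3=O)ccnc2c1` gives 25 nM

Compound 1 stands second highest of the three numbers, at 210 nM, and both of its neighbours lie beyond the scatter from it. Compound 4 `CNC(=O)CCCCCOc1ccc2c(OCCn3nc(-c4cnn(C)c4)ccc3=O)ccnc2c1` has not yet been measured. Its difference from compound 1 is methylcarbamoyl in place of (hydroxycarbamoyl)methyl on a saturated chain carbon, five bonds along the chain from an oxygen on an aromatic ring.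

Three measured steps at this same place bear on the change. With sulfanyl entering, the step is modest: a 3.0-fold higher number from compound 1 to compound 2 (0.48 log units; beyond the scatter). With acetyl entering, it is also modest but runs the other way: an 8.4-fold lower number from compound 1 to compound 3 (0.92 log units; beyond the scatter). The large step is a 26-fold lower number from compound 2 to compound 3 (1.41 log units; beyond the scatter). Compound 3 is the closest guide, since acetyl, like methylcarbamoyl, holds a carbonyl, and its value is 25 nM. Three compounds give no rule, however, and none of them carries methylcarbamoyl.

A modest drop is therefore expected in this assay, smaller than the drop seen with compound 3. The expected step is a 3.5-fold lower number from compound 1 to compound 4 (0.54 log units; beyond the scatter). For compound 4 the estimate is 60 nM, with an expected range of 15 nM to 220 nM.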

Compound 4, half-maximal inhibitory concentration: 79 nM
For compound 4 the middle estimate is 1.3-fold (0.12 log units) below the measured one; measured number inside the range.
By their numbers in this assay, from the lowest: compound 3; then compound 4; then compound 1; then compound 2.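

In this assay, the methylcarbamoyl chain end keeps a lower number than either earlier comparator (a 2.7-fold lower number from compound 1 to compound 4 (0.42 log units; beyond the scatter); an 8.1-fold lower number from compound 2 to compound 4 (0.91 log units; beyond the scatter)), so (hydroxycarbamoyl)methyl is not required at this place for activity in the cells. Compound 3 and compound 4 give the closest comparison yet at this chain end, with methylamino in place of methyl on a carbonyl carbon (a 3.2-fold higher number from compound 3 to compound 4 (0.50 log units; beyond the scatter)), which shows that the group on the carbonyl carbon shifts the number and that a carbonyl alone does not fix it, as compound 1 also holds a carbonyl yet has a higher number than both. No measurement available here accounts for this order among the chain ends.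

Where a carboxylic acid, a primary amide or an amine would fall at this chain end remains open, as does the place of an ester among the carbonyl-bearing ends. As far as these compounds go, it is also open whether a longer chain or a shorter chain carrying methylcarbamoyl or acetyl would keep the same order.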